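Tetrazolyl carboxamides on a fused oxygen core: desmethyl analogue

The compounds below may be only part of what the source reports. "The series", "measured", "known", "first", "only" and "open" are said of these compounds alone.

Measured so far:
compound 1 `CCOC(=O)C(=O)Nc1ccc2oc(C(=O)OCC)cc(=O)c2c1`: 12 ug/mL
compound 2 `Cc1ccc2oc(C(=O)Nc3nnn[nH]3)cc(=O)c2c1`: 0.075 ug/mL
compound 3 `O=C(Nc1nnn[nH]1)c1coc(=O)c2ccccc12`: > 18 ug/mL

In a functional assay on cells (Mast cell, Rattus norvegicus) for inhibition, with a stated time of 15 min (a higher number here means that more compound is needed for the effect, a lower number that less compound is needed), compound 2 gives 0.075 ug/mL, the lowest of the two numbers measured. Compound 1 gives 12 ug/mL, a far higher number, beyond the usual scatter. Compound 3 gives only a limit, > 18 ug/mL, with no number attached; this is the limit of > 18 ug/mL in this assay, at which 1 of the 3 values shown sits.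

Compound 4 `O=C(Nc1nnn[nH]1)c1cc(=O)c2ccccc2o1` has not yet been measured. It differs from compound 2 in one place: hydrogen in place of methyl on an aromatic carbon. Going by the values given here, no measured pair covers this change, so its size has to be judged without a direct precedent. The methyl is a single carbon with no polar atoms, and the remainder of the molecule, including the tetrazolyl amide, is unchanged. The expectation is therefore a small step, if any, from compound 2 to compound 4, most likely a slight rise in this assay and possibly nothing beyond the scatter.

For compound 4 the estimated value in this assay is 0.15 ug/mL, within 0.04 ug/mL to 0.6 ug/mL. This estimate corresponds to a step of a 2.0-fold higher number from compound 2 to compound 4 (0.30 log units; within the scatter) from compound 2, expected to be modest.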

Compound 4, concentration for half-maximal effect: 0.08 ug/mL
The estimate for compound 4 lay 1.9-fold (0.27 log units) above the measured number, within the range that was stated.
By their numbers in this assay, from the lowest: compounds 2 and 4 (each within the scatter of the next); then compound 1. At a limit, above all of these: compound 3.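

In this assay, going by these compounds alone, hydrogen in place of methyl on this aromatic carbon gives a 1.1-fold higher number from compound 2 to compound 4 (0.03 log units; within the scatter), the only direct pair so far. The methyl at this position, meta to a fused ring and para to a fused ring, is therefore not required for the low number seen with compound 2. No measurement shown bears on the reason for this result.

From the compounds shown here alone, whether the same aromatic carbon accepts something other than methyl or hydrogen stays open: an amine, a carboxylic acid, a methoxy group or a longer chain such as propyl would each extend the comparison. The contribution of the tetrazolyl amide also stays open, as the compounds shown hold no pair differing only there, for instance with a carboxylic acid in its place.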